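This account rests on a few compounds, and the source may have more. Where it says the series, first, only, none or still open, it means among the compounds named here.

Compound 1 `OC[C@H]1C[C@@H](Cn2cnc3c(-c4ccc(Cl)cc4)ncnc32)c2ccccc21`: 8440 nM
Compound 2 `COc1ccc(-c2ncnc3c2ncn3C[C@@H]2C[C@H](CO)c3ccccc32)cc1`: 17600 nM
Compound 3 `OC[C@H]1C[C@@H](Cn2cnc3c(-c4ccccc4)ncnc32)c2ccccc21`: 28100 nM

All three were tested in an ADME assay on L1210/0 cells (Mus musculus) for cytotoxicity, with a stated time of 48 h; on this read-out higher numbers stand for weaker inhibition and lower numbers for stronger inhibition. Compound 3 gives the highest number of the three; the step of a 1.6-fold higher number from compound 2 to compound 3 (0.20 log units; within the scatter) stays within the scatter, whereas a 3.3-fold higher number from compound 1 to compound 3 (0.52 log units; beyond the scatter) lies beyond it. Compound 4 `OC[C@H]1C[C@@H](Cn2cnc3c(NC4CC4)ncnc32)c2ccccc21` has not been measured. It differs from compound 3 in one place: cyclopropylamino in place of phenyl on an aromatic carbon. For the measured compounds named here, the measured steps of a 2.1-fold higher number from compound 1 to compound 2 (0.32 log units; beyond the scatter) and a 3.3-fold higher number from compound 1 to compound 3 (0.52 log units; beyond the scatter) and a 1.6-fold higher number from compound 2 to compound 3 (0.20 log units; within the scatter) all concern a small group on the phenyl that leaves here, so none of them bears directly on this change, and the expectation rests on no precedent and must be wide. The estimate for compound 4 is 30000 nM, with a range from 8000 nM to 100000 nM, which means an expected step of a 1.1-fold higher number from compound 3 to compound 4 (0.03 log units; within the scatter) that may well stay within the scatter.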

Compound 4, half-maximal inhibitory concentration: > 200000 nM
Compound 4: only a limit was reported; the forecaster's own chance of this, stated with the estimate: 20%; at least 6.6-fold (0.82 log units) between middle value and limit.
By their numbers in this assay, from the lowest: compound 1; then compounds 2 and 3 (each within the scatter of the next). At a limit, above all of these: compound 4.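

In this assay compound 4 is reported only as a limit, > 200000 nM. The earlier compounds shown here varied only a small group on the phenyl, whereas replacing the whole aromatic group on this carbon with cyclopropylamino gives an at least 7.1-fold higher number from compound 3 to compound 4 (0.85 log units; beyond the scatter), an at least 11-fold higher number from compound 2 to compound 4 (1.05 log units; beyond the scatter) and an at least 23-fold higher number from compound 1 to compound 4 (1.37 log units; beyond the scatter). This position can therefore shift the read-out strongly, and the cyclopropylamino change pushes it to the limit of the assay.

The compounds shown do not separate the loss of the phenyl from the arrival of the amine nitrogen. As far as these compounds go, whether a thienyl ring or a benzylamino group on this carbon would behave like phenyl or like cyclopropylamino remains open.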